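Swapping the aryl group on the ring amine of compound 1

This account rests on a few compounds, and the source may have more. Where it says the series, first, only, none or still open, it means among the compounds named here.

Measured compounds:
compound 1, `CCCc1nc(-c2ccccc2)c(CNCCN2CCN(c3ccccc3OC)CC2)o1`: 39.7%
compound 2, `Cc1nc(-c2ccccc2)c(CNCCCN2CCN(c3ccc(Cl)cc3)CC2)o1`: 38.1%
compound 3, `CCCc1nc(-c2ccccc2)c(CNCCCN2CCN(c3cccc(Cl)c3)CC2)o1`: 65.9%

Of the compounds shown here, three sharing one core have been tested in an assay on HEK293 cells for inhibition of Voltage-dependent T-type calcium channel subunit alpha-1G (Homo sapiens), read by fluorescence, tested at 10 uM; on this read-out lower numbers stand for less inhibition and higher numbers for more inhibition at the one concentration tested (going by the name of the read-out). Compound 1 stands second highest of the three numbers. Its nearest neighbour is compound 2, whose value lies within the scatter of that of compound 1, so the two cannot be ordered. The furthest is compound 3, which sits well beyond the scatter above compound 1.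

The next compound, compound 4 `CCCc1nc(-c2ccccc2)c(CNCCN2CCN(c3cccc(Cl)c3)CC2)o1`, keeps everything of compound 1 except the aryl group on the ring amine: 3-chlorophenyl in place of 2-methoxyphenyl on an amine nitrogen in a ring. For the measured compounds named here, no pair of measured compounds differs in exactly one place, so no measured step exists for comparison. Compound 3 carries the same 3-chlorophenyl that enters here, but it also differs from compound 1 elsewhere, so its higher value can only hint at the direction.

On that basis compound 4 is expected to come out above compound 1 in this assay, with a step of a number 15.3 percentage points higher from compound 1 to compound 4 (beyond the scatter) that is estimated to lie beyond the scatter but short of the full gap to compound 3. The estimate for compound 4 is 55%, within a range from 38% to 72%.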

Compound 4, a percentage reported as inhibition, at one concentration (the size of the read-out at that concentration, not a potency): 51.2%
Beside the measured number, compound 4's estimate is 3.8 percentage points above it; low and high end bracket the measured number.
By their numbers in this assay, from the lowest: compounds 2 and 1 (each within the scatter of the next); then compound 4; then compound 3.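

For the compounds shown here, this is the first change that can be read on its own: in this assay, the exchange of 2-methoxyphenyl for 3-chlorophenyl on the amine nitrogen in the ring gives a number 11.5 percentage points higher from compound 1 to compound 4 (beyond the scatter). The aryl group at this position therefore affects the read-out on its own, with the rest of compound 1 held fixed, and the step is modest but lies beyond the scatter. The change replaces one substituted phenyl with another, so the kind of substituent and its place on the ring change together, and the hydrogen-bond acceptor counted in 2-methoxyphenyl is lost in the same step; no measurement at hand explains the rise.

The compounds shown leave open whether the gain comes from adding the chlorine or from losing the methoxy group, a question that a plain phenyl group at this position could begin to separate. They also leave open how a fluorophenyl or bromophenyl group would compare there, and, with only one concentration tested, how the step would translate into potency.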